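Series notes: double-bond geometry from compound 2 to compound 3

A few compounds are considered here, and "the series" means these few. Any claim that something is new, unique, unknown or untested is made for them only; others in the source may bear on it.

Measured so far:
compound 1, `CCCCC/C(=C/C=C/C(=O)N[C@H](C)CCCc1cccnc1)c1ccc(OC)cc1`, 0.78 mg/kg
compound 2, `COc1ccc(/C(=C/C=C/C(=O)N[C@H](C)CCCc2cccnc2)c2ccccc2)cc1`, 0.16 mg/kg

Among the measured compounds shown here, in a functional assay with platelet-activating factor receptor (Cavia porcellus) as the target (a lower number here means that less compound is needed, a higher number that more compound is needed for the effect), compound 2 gives 0.16 mg/kg, the lowest of the two numbers so far. The nearest neighbour in this assay is compound 1, which gives 0.78 mg/kg, a higher number lying beyond the usual scatter. For the measured compounds named here, the two measured compounds differ in more than one place, so no single-point step between them is available for comparison.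

Compound 3, `COc1ccc(/C(=C\C=C\C(=O)N[C@H](C)CCCc2cccnc2)c2ccccc2)cc1`, is not yet measured in this assay. Relative to compound 2 the change is: the two compounds have the same atoms and bonds and differ only in configuration as drawn: 1 of 3 stereo elements differ; a double bond is drawn E in compound 2 and Z in compound 3. Going by the values given here, no measured pair shows a step of this kind, so its size can only be guessed. A change of double-bond geometry in the dienamide of this series is expected to cost activity, that is, to move the number upward beyond the scatter rather than leave it unchanged. Compound 3 is therefore expected to give 0.6 mg/kg, with a range from 0.15 mg/kg to 3 mg/kg. The expected step is a 3.8-fold higher number from compound 2 to compound 3 (0.57 log units; beyond the scatter).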

Compound 3, dose for 50% inhibition: 0.5 mg/kg
The estimate for compound 3 lay 1.2-fold (0.08 log units) above the measured number; the measured number falls inside the stated range.
By their numbers in this assay, from the lowest: compound 2; then compounds 3 and 1 (each within the scatter of the next).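

In this assay the series now has its first step at a single point, a 3.1-fold higher number from compound 2 to compound 3 (0.49 log units; beyond the scatter), and this step comes from double-bond geometry alone, since nothing enters or leaves: the fact that compounds 2 and 3 differ only in the configuration as drawn The geometry of this double bond therefore registers in the number for the phenyl compounds, although the step is modest. The second step, a 1.6-fold lower number from compound 1 to compound 3 (0.19 log units; within the scatter), exchanges phenyl for pentyl on a double-bonded chain carbon bound to an aromatic carbon and a double-bonded chain carbon, and it leaves compound 1 and compound 3 within the scatter of each other, so this pair alone gives no sign that the choice between phenyl and pentyl matters at this position.

From the compounds shown here alone, whether the geometry step holds with pentyl at this carbon remains open, and so does the effect of a shorter chain such as methyl, or of a saturated ring such as cyclohexyl, in the same place. The compounds shown also leave open what a change of geometry at the other double bond of the dienamide would do to the number.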